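Fluoro on a Compound Sitting at the Assay Limit

The source may report more compounds than this note shows. Statements on the series, on what has been measured and on what is new or still open speak of the compounds shown alone.

In a functional assay on HT-29 cells (Homo sapiens) for inhibition, read by CCK-8 assay, with a stated time of 24 h (on this read-out higher numbers stand for weaker inhibition and lower numbers for stronger inhibition), compound 1 `Cc1ccccc1-n1cc(-c2ccc(/C=C3\C(=O)Nc4ccccc43)cc2)nn1` gives a true number, 8710 nM. Compound 2 `O=C1Nc2ccccc2/C1=C/c1ccc(-c2cn(-c3ccccc3Cl)nn2)cc1` gives > 20000 nM, which is a limit. From the compounds shown here alone, compound 3 `O=C1Nc2ccccc2/C1=C/c1ccc(-c2cn(-c3cccc(Cl)c3)nn2)cc1` gives > 20000 nM, also a limit, so its true place is unknown. This is the limit of > 20000 nM in this assay, at which 2 of the 3 values shown sit. Compound 4 `O=C1Nc2ccc(F)cc2/C1=C/c1ccc(-c2cn(-c3cccc(Cl)c3)nn2)cc1` changes compound 3 in the shared core: fluoro in place of hydrogen on an aromatic carbon. The measured steps all lie elsewhere, on the group carried by the aromatic nitrogen or on its substituent: an at least 2.2-fold higher number from compound 1 to compound 2 (0.36 log units; beyond the scatter), an at least 2.2-fold higher number from compound 1 to compound 3 (0.36 log units; beyond the scatter) and a step that the two limits leave unreadable from compound 2 to compound 3. None tests fluoro, so no step beyond the scatter is expected in this assay. The expected change is a number no higher from compound 3 to compound 4 (the limit leaves the size open). For compound 4 the estimate is 20000 nM, with an expected range of 7000 nM to 50000 nM.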

Compound 4, half-maximal inhibitory concentration: 10500 nM
Compound 4: middle estimate off by 1.9-fold (0.28 log units), on the high side; the measured number falls inside the stated range.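

Fluoro in place of hydrogen on the shared core gives, in this assay, an at least 1.9-fold lower number from compound 3 to compound 4 (0.27 log units; that floor lies within the scatter). Within the data shown here, this is the first look at a change on the core itself, and it shows that a fluoro on this aromatic carbon still leaves a readable number. The true size of the step stays unknown because compound 3 sits at a limit: the limit of > 20000 nM in this assay, at which 2 of the 4 values shown sit.

From the compounds shown here alone, whether a chloro, a methoxy or an amine on this same carbon would behave like fluoro remains open. So does what fluoro would do on compound 1, with its 2-methylphenyl group.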